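The source may hold more compounds than are shown below. What is called first, only, known or untested is meant among the compounds shown, and "the series" means these compounds.

Three compounds of one shared core have been set against each other in an ADME assay on Vero cells (Chlorocebus sabaeus) for cytotoxicity, read by MTT assay, with a stated time of 24 h; a lower number here means that less compound is tolerated, a higher number that more compound is tolerated. Compound 1 `COc1ccc(Cn2c(SC(C)C(=O)Nc3ccc(C)cc3Cl)nc3ccccc32)cc1` reaches only a limit in this assay, > 75000 nM, so that the limit of > 75000 nM in this assay, at which 1 of the 3 values shown sits, gives no number for it. For compound 3 `CCOc1ccc(-n2c(SC(C)C(=O)Nc3cc(C)cc(C)n3)nc3ccccc32)cc1` this assay reports "not determined" (no result reported). Within the data shown here, compound 2 `COc1ccc(-n2c(SC(C)C(=O)Nc3ncc(C(F)(F)F)cc3Cl)nc3ccccc32)cc1` thus stands as the only compound with a measured number in this assay, 9200 nM. Compound 4 `COc1ccc(-n2c(SC(C)C(=O)Nc3nc(C)c(Cl)cc3Cl)nc3ccccc32)cc1` has not yet been measured. It differs from compound 2 in one place only: 3,5-dichloro-6-methylpyridin-2-yl in place of 3-chloro-5-(trifluoromethyl)pyridin-2-yl on an amide-type nitrogen. Among the measured compounds shown here, no step between two measured compounds is available, so no size of effect can be drawn from the data. The change is expected to stay within the usual scatter, with no clear direction, as a 1.3-fold higher number from compound 2 to compound 4 (0.12 log units; within the scatter). Compound 4 is therefore estimated at 12000 nM, somewhere between 4000 nM and 40000 nM.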

Compound 4, half-maximal cytotoxic concentration: 7250 nM
Estimate against measurement, compound 4: 1.7-fold (0.22 log units) above; low and high end bracket the measured number.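

This gives the first size of effect at the amide-type nitrogen: in this assay there is a 1.3-fold lower number from compound 2 to compound 4 (0.10 log units; within the scatter), and this is the only step shown between two measured compounds. On this reading, 3,5-dichloro-6-methylpyridin-2-yl and 3-chloro-5-(trifluoromethyl)pyridin-2-yl cannot be told apart in this measurement, so the trifluoromethyl group can give way to a chlorine and a methyl group without a clear effect. Nothing measured here offers an explanation for this result. Still open, from the compounds shown here alone, is whether an amine or a carboxylic acid on this pyridine ring would move the number beyond the scatter. One step at one position also cannot show how other changes would behave.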